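A few compounds are considered here, and "the series" means these few. Any claim that something is new, unique, unknown or untested is made for them only; others in the source may bear on it.

- compound 1 `CCN(C)C(=O)/C=C1\CCc2c(F)cc(F)cc21`: 56 mg/kg
- compound 2 `NC(=O)/C=C1/CCc2ccc(F)cc21`: 64 mg/kg

In a functional assay on the whole organism with Mus musculus as the target (on this read-out lower numbers stand for an effect already at smaller amounts and higher numbers for an effect only at larger amounts of compound), compound 1 stands within the usual scatter of compound 2, so neither can be ranked ahead of the other. Compound 3 `NC(=O)/C=C1\CCc2c(F)cc(F)cc21` comes from compound 1 through one change: amino in place of ethyl(methyl)amino on a carbonyl carbon. Within the data shown here, no measured pair shows this change alone. Compound 2 also carries the amino group, differs elsewhere, and gives 64 mg/kg. No shift beyond the scatter is therefore expected in this assay, in either direction. The expected 1.1-fold higher number from compound 1 to compound 3 (0.03 log units; within the scatter) is correspondingly small. For compound 3, the estimated value is 60 mg/kg, with an expected range of 25 mg/kg to 140 mg/kg.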

Compound 3, dose for half-maximal effect: 69 mg/kg
Compound 3: the middle estimate sits 1.2-fold (0.06 log units) below what was measured; low and high end bracket the measured number.
By their numbers in this assay, from the lowest: compounds 1, 2 and 3 (each within the scatter of the next).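

Among these compounds, putting amino in place of ethyl(methyl)amino on a carbonyl carbon gives a 1.2-fold higher number from compound 1 to compound 3 (0.09 log units; within the scatter) in this assay, the first direct reading of this change on one shared core. At this position, the two groups therefore cannot be told apart in this assay. Nothing measured here explains this result. As far as these compounds go, it remains open whether a methylamino group, a longer chain on the nitrogen or a ring amine such as morpholine would read the same. From the compounds shown here alone, a carboxylic acid in place of the amide also remains untested by these compounds.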